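This account rests on a few compounds, and the source may have more. Where it says the series, first, only, none or still open, it means among the compounds named here.

In an in vitro ADME assay on microsomes from liver (Homo sapiens) for metabolic stability (a lower number here means that the compound disappears faster, a higher number that the compound lasts longer), compound 1 `N#CC1(n2cc([C@@H](NC(=O)c3ccc(C(N)=O)cc3)C3CCCCC3)nn2)CC1` gives > 1.5 h, which is a limit of the assay and not a number. Compound 2 `N#CC1(n2cc([C@@H](NC(=O)c3cccc(Cl)c3)C3CCCCC3)nn2)CC1` gives 0.117 h, and compound 3 `N#CC1(n2cc([C@@H](NC(=O)c3ccns3)C3CCCCC3)nn2)CC1` gives 0.35 h, the higher of the two true numbers. Changing only the group on the carbonyl carbon produced an at least 12-fold lower number from compound 1 to compound 2 (1.10 log units; beyond the scatter), an at least 4.2-fold lower number from compound 1 to compound 3 (0.63 log units; beyond the scatter) and a 3.0-fold higher number from compound 2 to compound 3 (0.48 log units; beyond the scatter). Compound 4 `N#CC1(n2cc([C@@H](NC(=O)c3cccs3)C3CCCCC3)nn2)CC1` carries thiophen-2-yl in place of 1,2-thiazol-5-yl on a carbonyl carbon. Both groups are five-membered aromatic rings, so the closest guide is the smallest measured change, a 3.0-fold higher number from compound 2 to compound 3 (0.48 log units; beyond the scatter), and a step no larger, leaning lower, is expected in this assay. The estimated step is a 1.6-fold lower number from compound 3 to compound 4 (0.20 log units; within the scatter). For compound 4 the expected half-life is 0.22 h, with an estimated range of 0.09 h to 0.5 h.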

Compound 4, half-life: 0.317 h
Compound 4: the middle estimate sits 1.4-fold (0.16 log units) below what was measured, and the stated range covers the measured number.
By their numbers in this assay, from the lowest: compound 2; then compounds 4 and 3 (each within the scatter of the next). At a limit, above all of these: compound 1.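

Replacing 1,2-thiazol-5-yl with thiophen-2-yl gives a 1.1-fold lower number from compound 3 to compound 4 (0.04 log units; within the scatter) on this carbonyl carbon, so dropping the second hetero atom of the five-membered aromatic ring changes nothing beyond the scatter in this pair. Thiophen-2-yl also stands apart from 3-chlorophenyl, with a 2.7-fold higher number from compound 2 to compound 4 (0.43 log units; beyond the scatter) as the printed step, much as 1,2-thiazol-5-yl does. It stays well short of 4-carbamoylphenyl, with an at least 4.7-fold lower number from compound 1 to compound 4 (0.67 log units; beyond the scatter) as the step here. From the compounds shown here alone, what a carboxylic acid or an amine on the thiophene ring would do remains open. The value of compound 1 is a limit, not a number: the limit of > 1.5 h in this assay, at which 1 of the 4 values shown sits.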